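The source may report more compounds than this note shows. Statements on the series, on what has been measured and on what is new or still open speak of the compounds shown alone.

Measured so far:
- compound 1, `Cc1ccn2c(C)c(C)nc2c1OCc1ccccc1`: 35%
- compound 2, `Cc1nc2c(OCc3ccccc3)cccn2c1N`: 96%
- compound 3, `CCCCc1nc2c(OCc3ccccc3)cccn2c1N`: 0%

In a functional assay on the whole organism with Canis familiaris (Canis lupus familiaris) as the target, at a dose of 8 mg/kg by the oral route (a higher number here means a stronger effect of the compound at the dose given, a lower number a weaker effect), compound 2 gives the highest of the three numbers; compound 1 comes nearest, and compound 3 lies furthest away, both gaps being beyond the scatter. The unmeasured compound 4, `Cc1ccn2c(N)c(C)nc2c1OCc1ccccc1`, differs from compound 2 in one place: methyl in place of hydrogen on an aromatic carbon.

Going by the values given here, only one measured step is available, a number 96 percentage points lower from compound 2 to compound 3 (beyond the scatter), and it concerns a different kind of change, a chain carbon rather than an aromatic carbon, so it does not speak directly to the change at hand. Among the compounds with values here, compound 1 does carry a methyl on the aromatic carbon in question, but it also has a methyl where compound 2 has an amino group, and no single step separates those two changes; its value in this assay is only a hint that the methyl may cost something. The expectation is therefore a modest loss, estimated as a number 21 percentage points lower from compound 2 to compound 4 (beyond the scatter), with wide uncertainty. Compound 4 is expected to give about 75% in this assay, within a range from 40% to 98%.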

Compound 4, a percentage reported as inhibition, in the whole organism at one dose (the size of the read-out at that dose, not a potency): 64%
The estimate for compound 4 lay 11 percentage points above the measured number; the measured number falls inside the stated range.
By their numbers in this assay, from the lowest: compound 3; then compound 1; then compound 4; then compound 2.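

In this assay, going by these compounds alone, placing a methyl on the aromatic carbon opposite the ring nitrogen gives a number 32 percentage points lower from compound 2 to compound 4 (beyond the scatter), the first measured step at this position, and compound 4 still keeps a clear effect at 64%. Compound 4 also isolates the amino group from that ring methyl: amino in place of methyl gives a number 29 percentage points higher from compound 1 to compound 4 (beyond the scatter), so with the ring methyl held constant, the amino group is linked to a higher number than methyl. Compound 1 and compound 2 differ in two places and could not provide this comparison. Nothing available here measures any property that could explain either step.

On these data alone, it remains open whether the drop at this aromatic carbon is particular to methyl or would also follow from an ethyl group, a methoxy group or a chlorine atom in the same place. The compounds shown also leave open how a dimethylamino or acetamide group would compare with the amino group, with or without the ring methyl.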